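The compounds below may be only part of what the source reports. "The series", "measured", "known", "first", "only" and "open" are said of these compounds alone.

Measured compounds and values in an ADME assay on BJ cells (Homo sapiens) for cytotoxicity, read by CellTiter-Glo and resazurin assay, with a stated time of 72 h; on this read-out higher numbers stand for an effect only at larger amounts of compound and lower numbers for an effect already at smaller amounts:

Compound 1 `CCCNCc1cccc(OCCCCCC(=O)OCC)c1` gives > 26000 nM; this is a limit of the assay, not a number.
Compound 2 `CCCNCc1ccc(OCCCCCC(=O)OCC)cc1` gives > 26000 nM; again a limit, not a number.
Compound 3 `CCOC(=O)CCCCCOc1cccc(C=O)c1` gives > 26000 nM; also a limit, not a number.

All three values sit at the same point, (the limit of > 26000 nM in this assay, at which 3 of the 3 values shown sit). The difference between the core of compound 1 and the core of compound 2 is not broken down here. Compound 3 arises from compound 1 by formyl in place of (propylamino)methyl on an aromatic carbon. The step that the two limits leave unreadable from compound 1 to compound 3 cannot be sized, since both ends are limits.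

Compound 4 `CCOC(=O)CCCCCOc1ccc(C=O)cc1` is not yet measured in this assay. It arises from compound 2 by formyl in place of (propylamino)methyl on an aromatic carbon. Among the measured compounds shown here, this is the same kind of change as the one from compound 1 to compound 3, not the same: there the formyl sits meta to a large group, here para to a large group.

For compound 4 the expected step that the limit leaves unreadable from compound 2 to compound 4 in this assay is set to lie near zero, resting on the fact that compound 1, compound 2 and compound 3 all sit at the limit of > 26000 nM in this assay, at which 3 of the 3 values shown sit, so that the same kind of change seen from compound 1 to compound 3 gave no readable movement. The estimate for compound 4 in this assay is 40000 nM, between 26000 nM and 150000 nM, and most likely the assay again reports only a limit.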

Compound 4, half-maximal effective concentration: > 26000 nM
Compound 4 gave a limit, no number; the forecaster's own chance of this, stated with the estimate: 90%; the middle value is on the limit's open side.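

In this assay compound 4 gives > 26000 nM, a limit of the assay and not a number. No step can be read from compound 2 to compound 4, because both ends are limits, as are all values in the series: the limit of > 26000 nM in this assay, at which 4 of the 4 values shown sit. The compounds shown leave open how large the change from (propylamino)methyl to formyl is, and whether any member of this series reaches a measurable value in this assay.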